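Quinoline series: solubility notes toward compound 3

A few compounds are considered here, and "the series" means these few. Any claim that something is new, unique, unknown or untested is made for them only; others in the source may bear on it.

Measured so far in a physicochemical assay for solubility, with a stated time of 18 h, at pH 7.4; on this read-out higher numbers stand for higher solubility and lower numbers for lower solubility:
- compound 1, `COc1cccc(CNCCCNc2ccnc3cc(Cc4ccc(F)cc4)ccc23)c1O`: 4200 nM
- compound 2, `COc1cccc(CNCCCNc2ccnc3cc(Oc4cccc(N(C)C)c4)ccc23)c1O`: 14500 nM

For the measured compounds named here, compound 2 stands at the higher of the two numbers measured so far; the nearest and only other point is compound 1, and the step of a 3.5-fold higher number from compound 1 to compound 2 (0.54 log units; beyond the scatter) separates them beyond the scatter. Going by the values given here, that step, in which 3-(dimethylamino)phenoxy replaced 4-fluorobenzyl on an aromatic carbon, is the single piece of measured change available.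

Compound 3, `COc1cccc(CNCCCNc2ccnc3cc(CC4CCCCC4)ccc23)c1O`, has not yet been measured. Its structural difference from compound 2 is cyclohexylmethyl in place of 3-(dimethylamino)phenoxy on an aromatic carbon. The group entering, cyclohexylmethyl, shares with the 4-fluorobenzyl of compound 1 a one-carbon link to a six-membered ring, while the leaving 3-(dimethylamino)phenoxy is the group that carried compound 2 to its higher number. Among the compounds with values here, only the step between compound 1 and compound 2 bears on this change, and it runs in the opposite sense. Within the data shown here, for compound 3 the step of a 5.8-fold lower number from compound 2 to compound 3 (0.76 log units; beyond the scatter) is therefore expected, downward, because a 3.5-fold higher number from compound 1 to compound 2 (0.54 log units; beyond the scatter) is the only guide and is here being undone in part. Compound 3 is estimated at 2500 nM, with a range from 800 nM to 8000 nM.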

Compound 3, solubility: 4200 nM
Compound 3: middle estimate off by 1.7-fold (0.23 log units), on the low side, and the stated range covers the measured number.
By their numbers in this assay, from the lowest: compounds 1 and 3 (each within the scatter of the next); then compound 2.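

In this assay, the step of no change at the digits printed from compound 1 to compound 3 (within the scatter) shows that, with the one-carbon link kept at this position, a terminal cyclohexyl and a terminal 4-fluorophenyl cannot be told apart, so an aromatic and a non-aromatic six-membered ring of carbon only give the same reading here. The step of a 3.5-fold lower number from compound 2 to compound 3 (0.54 log units; beyond the scatter) shows that the gap around compound 2 is not tied to 4-fluorobenzyl alone: a second group on the same aromatic carbon, without fluorine and without an aromatic ring, also falls short of compound 2 beyond the scatter, leaving compound 2 as the one point apart among the three. No evidence on hand accounts for these readings.

Compound 2 differs from compounds 1 and 3 both in its oxygen link and in its dimethylamino group, and the three compounds do not separate these two features. A plain phenoxy group and a benzyl group carrying dimethylamino at this position would each isolate one feature, while a morpholine or a carboxylic acid on the terminal ring would show whether other heteroatom-bearing groups also stand apart from compounds 1 and 3.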